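The compounds below may be only part of what the source reports. "The series", "measured", "known", "first", "only" and "open" are said of these compounds alone.

In a functional assay on HEL cells (Homo sapiens) (on this read-out higher numbers stand for lower toxicity in this test and lower numbers for higher toxicity in this test), compound 1 (`CCCCCCCc1cc2cn(COCCO)c(O)nc-2n1`) gives 119000 nM and compound 2 (`CCCCCCCCCCCc1cc2cn(COCCO)c(=O)nc2o1`) gives 132000 nM, two values within the usual scatter of each other. Compound 3 (`CCCCCCCCCc1cc2cn(COCCO)c(=O)nc2o1`) stands at >= 100000 nM, which is a limit and not a number. This is the limit of >= 100000 nM in this assay, at which 1 of the 3 values shown sits.

Compound 4 (`CCCCCc1cc2cn(COCCO)c(=O)nc2o1`) keeps the shared core of compound 3 and shortens the chain, with hydrogen in place of butyl on a saturated chain carbon, five bonds along the chain from an aromatic carbon.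

The closest measured change is also a cut in the same chain, but a step that the limit leaves unreadable from compound 2 to compound 3 gives no size to carry over. The remaining guide is indirect. Compound 1, with a shorter chain on a core of its own, gives 119000 nM, and compound 2, with a longer chain, gives 132000 nM. These two values show no sign that chain length moves this read-out, although three compounds are a thin basis and the core of compound 1 differs.

In this assay the expectation for a step that the limit leaves unreadable from compound 3 to compound 4 is therefore no change beyond the scatter, in either direction. Compound 4 is estimated at 130000 nM, with an expected range from 60000 nM to 300000 nM.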

Compound 4, half-maximal cytotoxic concentration: > 200000 nM
Compound 4: no number, only a limit; the forecaster's own chance of this, stated with the estimate: 55%; middle value at least 1.5-fold (0.18 log units) from the limit.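

In this assay compound 4 stands at > 200000 nM, which is a limit of the assay and not a number. Putting hydrogen in place of hexyl on the chain gives an at least 1.5-fold higher number from compound 2 to compound 4 (0.18 log units; that floor lies within the scatter), so this shorter chain on the shared core shows no sign of higher toxicity in this test, although the smallest size the step could have lies within the usual scatter. The step between compound 3 and compound 4 cannot be read, as each of the two carries only a limit: the limit of > 200000 nM in this assay, at which 1 of the 4 values shown sits.

The compounds shown leave open whether any chain length on the shared core brings a toxicity that can be given as a number below these values in this assay, as compound 2 is the only compound on this core with a measured number rather than a limit. A phenyl group or an amine in place of the chain of compound 4 would show whether this position responds to anything other than a change in chain length.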